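The compounds below may be only part of what the source reports. "The series", "measured", "known", "first", "only" and "open" are said of these compounds alone.

Among the compounds with values here, in a functional assay on MCF7 cells (Homo sapiens) for antiproliferative activity, read by MTT assay, with a stated time of 48 h (on this read-out higher numbers stand for weaker inhibition and lower numbers for stronger inhibition), compound 3 (`CCn1c(C(=O)NC(CC(=O)O)C(=O)OC)ccc1C(CC)(CC)c1ccc(OCCC(O)(CC)CC)c(C)c1`) gives 10200 nM, the only actual number in this set. Compound 1 (`CCn1c(C(=O)N(CCC#N)CCC#N)ccc1C(CC)(CC)c1ccc(OCCC(O)(CC)CC)c(C)c1`) reads > 50000 nM, which is a limit of the assay. Compound 2 (`C=CCN(C)C(=O)c1ccc(C(CC)(CC)c2ccc(OCCC(O)(CC)CC)c(C)c2)n1CC`) reads > 50000 nM, also a limit. Compound 4 (`CCn1c(C(=O)NC(C)CO)ccc1C(CC)(CC)c1ccc(OCCC(O)(CC)CC)c(C)c1`) departs from compound 3 on an amide-type nitrogen: a group of 4 heavy atoms (3 carbon, 1 oxygen; no ring) in place of a group of 9 heavy atoms (5 carbon, 4 oxygen; no ring), on an amide-type nitrogen, the entering group being 1-(hydroxymethyl)ethyl. The nearest evidence comes from two changes of the group on the carbonyl carbon: an at least 4.9-fold lower number from compound 1 to compound 3 (0.69 log units; beyond the scatter) and an at least 4.9-fold lower number from compound 2 to compound 3 (0.69 log units; beyond the scatter). Both favour the group-bearing compound 3, so losing that group is expected to raise the number modestly in this assay, although neither step tests this exact replacement. The expected change is a 2.5-fold higher number from compound 3 to compound 4 (0.39 log units; beyond the scatter). Compound 4 is estimated at 25000 nM, with an expected range of 8000 nM to 70000 nM.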

Compound 4, half-maximal inhibitory concentration: 12600 nM
Compound 4: middle estimate off by 2.0-fold (0.30 log units), on the high side; low and high end bracket the measured number.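

Replacing the group of 9 heavy atoms on the amide-type nitrogen with 1-(hydroxymethyl)ethyl gives a 1.2-fold higher number from compound 3 to compound 4 (0.09 log units; within the scatter), so that larger group is not required for the activity of compound 3. The two amides without the amide hydrogen stay clearly apart: an at least 3.9-fold lower number from compound 2 to compound 4 (0.59 log units; beyond the scatter) and an at least 3.9-fold lower number from compound 1 to compound 4 (0.59 log units; beyond the scatter). Both steps are lower bounds set by a limit: the limit of > 50000 nM in this assay, at which 2 of the 4 values shown sit.

Still open, going by these compounds, is whether a plain propyl chain, or an amine in place of the hydroxyl, on the amide-type nitrogen would hold the number. The compounds shown also do not separate the role of the amide hydrogen from the other differences in the two limit compounds.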